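The source may hold more compounds than are shown below. What is called first, only, known or untested is meant among the compounds shown, and "the series" means these compounds.

Of the compounds shown here, two have been measured so far. In a functional assay on HT-1080 cells (Homo sapiens), read by transwell migration, with a stated time of 24 h, tested at 0.1 uM (a higher number here means a weaker effect of the compound at the concentration tested, a lower number a stronger effect), compound 1 `CC(=O)OCc1ccc2oc(=O)c(C(=O)Sc3cccc(Br)c3)cc2c1` gives 79.6%, while compound 2 `CCCCCC(=O)OCc1ccc2oc(=O)c(C(=O)Oc3cccc(Br)c3)cc2c1` gives 94.3%, the higher of the two numbers and separated from compound 1 by a gap beyond the usual scatter. Compound 3 `CC(=O)NCc1ccc2oc(=O)c(C(=O)Oc3cccc(Br)c3)cc2c1` has not been measured; it differs from compound 2 in a single place: acetamido in place of (pentylcarbonyl)oxy on a saturated chain carbon bound to an aromatic carbon. For the measured compounds named here, no measured pair isolates this change, so its effect is unknown. A modest lowering is expected, estimated as a step of a number 6.3 percentage points lower from compound 2 to compound 3 (within the scatter), which may well stay within the scatter. Compound 3 is accordingly expected to give about 88%, within a range from 72% to 100%.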

Compound 3, a percentage reported as activity, at one concentration (the size of the read-out at that concentration, not a potency): 34.4%
Compound 3: the middle estimate sits 53.6 percentage points above what was measured; the measured number lies below the stated range.
By their numbers in this assay, from the lowest: compound 3; then compound 1; then compound 2.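

Putting acetamido in place of (pentylcarbonyl)oxy gives a step of a number 59.9 percentage points lower from compound 2 to compound 3 (beyond the scatter) in this assay. The group on this saturated chain carbon bound to an aromatic carbon can therefore strongly change the read-out at the concentration tested. No measurement shown explains the step.

The change replaces both the chain length and the link to the chain, and the compounds shown do not separate the two. Hexanamido at this place would keep the longer chain with the amide link, while a free amine would remove the acyl part altogether.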